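Swapping a Nitro Group for a Pyridyl Enone

The compounds below may be only part of what the source reports. "The series", "measured", "known", "first", "only" and "open" are said of these compounds alone.

Compound 1 `CC(=O)OC[C@H]1O[C@@H](n2cc(Cn3cc(C(C)=O)c4ccccc43)nn2)[C@H](OC(C)=O)[C@@H](OC(C)=O)[C@@H]1OC(C)=O`: > 200000 nM in an ADME assay on NIH3T3 cells (Homo sapiens) for cytotoxicity, read by sulforhodamine B assay, with a stated time of 48 h; on this read-out lower numbers stand for stronger inhibition and higher numbers for weaker inhibition
Compound 2 `CC(=O)OC[C@H]1O[C@@H](n2cc(Cn3cc([N+](=O)[O-])c4ccccc43)nn2)[C@H](OC(C)=O)[C@@H](OC(C)=O)[C@@H]1OC(C)=O`: 20500 nM

For the measured compounds named here, only two compounds of this shared core have been measured. Compound 1 sits at the limit of this assay, > 200000 nM; that is a limit, not a number (the limit of > 200000 nM in this assay, at which 1 of the 2 values shown sits). Going by the values given here, compound 2 gives 20500 nM, the only real number in the set, so it stands alone as the reference point.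

Among the compounds with values here, the single measured step, an at least 9.7-fold lower number from compound 1 to compound 2 (0.98 log units; beyond the scatter), lies beyond the scatter. Compound 3 `CC(=O)OC[C@H]1O[C@@H](n2cc(Cn3cc(/C=C/C(=O)c4cccnc4)c4ccccc43)nn2)[C@H](OC(C)=O)[C@@H](OC(C)=O)[C@@H]1OC(C)=O` is not yet measured and differs from compound 2 by 2-((pyridin-3-yl)carbonyl)ethenyl in place of nitro on an aromatic carbon. Within the data shown here, the nitro group that leaves here is the very group that entered in the one step known, but no measured step shows what an enone-linked pyridine does on this core, so only a loose expectation is possible.

Compound 3 is estimated at 20000 nM, with a range from 4000 nM to 120000 nM, which would mean a step of a 1.0-fold lower number from compound 2 to compound 3 (0.01 log units; within the scatter), not clearly beyond the scatter in either direction.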

Compound 3, half-maximal inhibitory concentration: > 200000 nM
Compound 3 gave a limit, no number (the forecaster's own chance of this, stated with the estimate: 25%); middle value at least 10-fold (1.00 log units) from the limit.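

In this assay, the new step shows that the nitro group cannot be exchanged freely on this aromatic carbon of the five-membered ring: 2-((pyridin-3-yl)carbonyl)ethenyl in its place gives an at least 9.7-fold higher number from compound 2 to compound 3 (0.98 log units; beyond the scatter). Before this, only acetyl had been compared with nitro here, and now a second, quite different group also stands clearly apart from compound 2. Compound 3 gives a limit and not a number, so the step between it and compound 1, also a limit, cannot be read: the limit of > 200000 nM in this assay, at which 2 of the 3 values shown sit.

From the compounds shown here alone, it remains open whether the lower number of compound 2 belongs to nitro in particular or would also appear with another small group on this carbon, such as a nitrile or an amine. Also open, going by these compounds, is how a phenyl ring in place of the pyridine in the entering group would read in this assay.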